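The compounds below may be only part of what the source reports. "The series", "measured", "known", "first", "only" and "open" are said of these compounds alone.

Measured compounds:
Compound 1 `O=C(Nc1ccc(Cl)cc1)c1cc(=O)[nH]c2cc(Br)ccc12`
Compound 2 `O=C(Nc1ccc(F)cc1)c1cc(=O)[nH]c2cc(Br)ccc12`
Compound 3 `O=C(Nc1cc(F)cc(F)c1)c1cc(=O)[nH]c2cc(F)ccc12`

In a functional assay on KYSE-410 cells (Homo sapiens) for antiproliferative activity, read by MTT assay, with a stated time of 72 h (a lower number here means a stronger inhibitor, a higher number a weaker inhibitor), compound 1 gives only a limit, > 20000 nM. In this assay compound 2 likewise gives only a limit, > 20000 nM. Compound 3 also reaches only a limit in this assay, > 20000 nM. The step that the two limits leave unreadable from compound 2 to compound 1, made by chloro in place of fluoro on an aromatic carbon, cannot be read, because of the limit of > 20000 nM in this assay, at which 3 of the 3 values shown sit.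

Compound 4 `O=C(Nc1cc(F)cc(F)c1)c1cc(=O)[nH]c2cc(Cl)ccc12` is not yet measured. It differs from compound 3 by chloro in place of fluoro on an aromatic carbon. The difference between the core of compound 3 and the core of compound 2 is not broken down here. The change from compound 3 to compound 4 is the same kind of change as that from compound 2 to compound 1, but not the same: in the first case the place is para to a large group, in the second it is part of a fused or bridged system of two rings, meta to a fused ring and para to a fused ring.

With all three values sitting at the limit, compound 4 is expected in this assay at about 30000 nM, between 8000 nM and 100000 nM, most probably reported again only as a limit. This expectation means a step that the limit leaves unreadable from compound 3 to compound 4, resting on compound 3 and its value > 20000 nM.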

Compound 4, half-maximal inhibitory concentration: 11000 nM
Compound 4: the middle estimate sits 2.7-fold (0.44 log units) above what was measured; the measured number falls inside the stated range.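

In this assay, chloro in place of fluoro on an aromatic carbon that is part of a fused or bridged system of two rings gives an at least 1.8-fold lower number from compound 3 to compound 4 (0.25 log units; that floor lies within the scatter), so this step alone does not establish a gain beyond the scatter. Only compound 4, at 11000 nM, gives a number to work from. The same kind of change in a different place, para to a large group, cannot be read from compound 2 to compound 1, and no step in this set other than the one above can be read, because most of the values are limits: the limit of > 20000 nM in this assay, at which 3 of the 4 values shown sit.

The swap is therefore not shown to carry from one core to another, nor shown to fail to carry.

Still open, from the compounds shown here alone, is whether chloro at the same place on the core of compound 1 would also give a readable value. Also open, going by these compounds, is whether an amine, a carboxylic acid or a longer alkyl chain in place of the halogens would move the values of this series clear of the limit.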